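Isopropylamino on the Sulfonyl Chain: Stability Outlook

The source may hold more compounds than are shown below. What is called first, only, known or untested is meant among the compounds shown, and "the series" means these compounds.

Compound 1 `CCS(=O)(=O)NC(=O)c1ccc(Nc2nc(NC3(c4ccc(Cl)cc4)CC3)nc(OCC(F)(F)F)n2)cc1` stands highest of the three measured numbers in an ADME assay on microsomes from liver (Homo sapiens) for metabolic stability, with a stated time of 10 min (a lower number here means that less of the compound is left, a higher number that more of the compound is left), where compound 1 gives 100%. Its two neighbours carry a substituent on the same chain carbon: compound 2 `CNC(=O)NCCS(=O)(=O)NC(=O)c1ccc(Nc2nc(NC3(c4ccc(Cl)cc4)CC3)nc(OCC(F)(F)F)n2)cc1` gives 97% in this assay, and compound 3 `CC(=O)NCCS(=O)(=O)NC(=O)c1ccc(Nc2nc(NC3(c4ccc(Cl)cc4)CC3)nc(OCC(F)(F)F)n2)cc1` gives 95%. The steps of a number 3 percentage points lower from compound 1 to compound 2 (within the scatter) and a number 5 percentage points lower from compound 1 to compound 3 (within the scatter) are both within the scatter, as is a number 2 percentage points lower from compound 2 to compound 3 (within the scatter), so the three compounds are not told apart by this assay.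

Compound 4 `CC(C)NCCS(=O)(=O)NC(=O)c1ccc(Nc2nc(NC3(c4ccc(Cl)cc4)CC3)nc(OCC(F)(F)F)n2)cc1` differs from compound 1 in one place: isopropylamino in place of hydrogen on a saturated chain carbon, two bonds along the chain from a sulfonyl sulfur. The two steps that bear on this change are those from compound 1 to compound 2 and from compound 1 to compound 3, each of which also puts a group bearing a nitrogen onto that saturated chain carbon two bonds along the chain from the sulfonyl sulfur, and each stayed within the scatter. Compound 4 is therefore expected to give a step of a number 7 percentage points lower from compound 1 to compound 4 (within the scatter), that is, no change beyond the scatter in this assay. The estimate for compound 4 in this assay is 93%, with a range from 80% to 100%.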

Compound 4, percent of the compound remaining: 89%
Compound 4: middle estimate off by 4 percentage points, on the high side; the range from low to high includes it.
By their numbers in this assay, from the lowest: compounds 4, 3, 2 and 1 (each within the scatter of the next, the first and the last beyond it).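

In this assay, isopropylamino in place of hydrogen on a saturated chain carbon, two bonds along the chain from a sulfonyl sulfur, gives a number 11 percentage points lower from compound 1 to compound 4 (beyond the scatter) and is the only substituent shown at this position whose step from compound 1 lies beyond the scatter, although that step is modest. The three substituted compounds still cannot be separated, as isopropyl in place of acetyl on an amine nitrogen gives a number 6 percentage points lower from compound 3 to compound 4 (within the scatter) and isopropyl in place of methylcarbamoyl on an amine nitrogen gives a number 8 percentage points lower from compound 2 to compound 4 (within the scatter) in the same assay, so compound 4 differs clearly from compound 1 but not from compound 2 or compound 3. Nothing available explains why this step exceeds the scatter when the other two steps from compound 1 do not.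

With isopropylamino as the only group of its kind here, the compounds shown leave open whether this step belongs to the amine nitrogen or to the isopropyl group on it, which methylamino or an unsubstituted amine on the same chain carbon would address. Also open, from the compounds shown here alone, is how a morpholine, a carboxylic acid or a longer chain would fare at this position.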